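This account rests on a few compounds, and the source may have more. Where it says the series, first, only, none or still open, it means among the compounds named here.

Measured compounds:
- compound 1, `COc1cc(Cl)cc(-c2nn(-c3cccc(NC(=O)Nc4ccc(Cl)c(C(F)(F)F)c4)c3)cc2-c2ccncc2)c1`: -2.82%
- compound 2, `COc1cc(Cl)cc(-c2nn(-c3cccc(NC(=O)Nc4cc(C(F)(F)F)cc(C(F)(F)F)c4)c3)cc2-c2ccncc2)c1`: -5.97%
- compound 3, `COc1cc(Cl)cc(-c2nn(-c3cccc(NC(=O)Nc4ccc(Cl)c(Cl)c4)c3)cc2-c2ccncc2)c1`: 7.27%

All three were measured in a functional assay on NCI-H226 cells (Homo sapiens) for inhibition, read by sulforhodamine B assay, with a stated time of 48 h, tested at 10 uM; a higher number here means a weaker effect of the compound at the concentration tested, a lower number a stronger effect. Among the three, compound 3 gives the highest number, standing a number 10.1 percentage points higher from compound 1 to compound 3 (beyond the scatter) and further still from compound 2, so on these numbers it is the compound with the weakest effect.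

The step now followed leads from compound 3 to compound 4, `COc1cc(Cl)cc(-c2nn(-c3cccc(NC(=O)Nc4cccc(C(F)(F)F)c4)c3)cc2-c2ccncc2)c1`, not yet measured in this assay. The change is 3-(trifluoromethyl)phenyl in place of 3,4-dichlorophenyl on an amide-type nitrogen. For the measured compounds named here, only one measured step bears on this: a number 10.1 percentage points higher from compound 1 to compound 3 (beyond the scatter), a modest rise beyond the scatter when chloro replaced trifluoromethyl. Going by the values given here, compound 4 puts a trifluoromethyl back in place of a chloro and also drops the second chlorine, for which no measured pair gives guidance. Taking the measured step as a guide in reverse, compound 4 is expected to move back by roughly a number 10.3 percentage points lower from compound 3 to compound 4 (beyond the scatter) in this assay, landing near compounds 1 and 2. The estimate for compound 4 is therefore -3%, expected to fall between -14% and 8%.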

Compound 4, a percentage reported as activity, at one concentration (the size of the read-out at that concentration, not a potency): 3.94%
Estimate against measurement, compound 4: 6.9 percentage points below; measured number inside the range.
By their numbers in this assay, from the lowest: compounds 2, 1, 4 and 3 (each within the scatter of the next, the first and the last beyond it).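

In this assay, the exchange of 3,4-dichlorophenyl for 3-(trifluoromethyl)phenyl on the amide-type nitrogen gives a number 3.3 percentage points lower from compound 3 to compound 4 (within the scatter), so this swap, which changes two ring substituents at once, cannot be told apart from no change. Removing one substituent from a two-substituted ring is also unreadable: hydrogen in place of trifluoromethyl gives a number 9.9 percentage points higher from compound 2 to compound 4 (within the scatter), and hydrogen in place of chloro gives a number 6.8 percentage points higher from compound 1 to compound 4 (within the scatter), so in these two cases the second substituent makes no difference that stands out from the scatter. No measurement at hand explains these numbers.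

The compounds shown leave open what a plain phenyl with no substituent would give. They also leave open whether an amine or a carboxylic acid in place of the trifluoromethyl would move the read-out beyond the scatter.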